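Fluoro added to the aryl ether ring of compound 3

The source may hold more compounds than are shown below. What is called first, only, known or untested is meant among the compounds shown, and "the series" means these compounds.

Three compounds have numbers in an assay on HEK293 cells for inhibition of Toll-like receptor 8 (Homo sapiens), with a stated time of 16 h; a higher number here means a weaker inhibitor, a lower number a stronger inhibitor. Compound 1 `N#Cc1c(Cl)cccc1Oc1ccc(-c2nnco2)cc1` gives 1400 nM. Compound 2 `O=C(Nc1ccc(Oc2cc(C(F)(F)F)cc(C(F)(F)F)c2)cc1O)c1c(F)cccc1I` gives 2630 nM. Compound 3 `O=C(Nc1ccc(Oc2cccc(C(F)(F)F)c2)cc1)c1c(F)cccc1Cl` gives 2410 nM. Compound 3 stands second highest of the three; its nearest neighbour is compound 2, whose number lies within the scatter of that of compound 3, and compound 1, the furthest, also lies within the scatter. The three numbers thus cannot be told apart.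

Compound 4 `O=C(Nc1ccc(Oc2cc(F)cc(C(F)(F)F)c2)cc1)c1c(F)cccc1Cl` is not yet measured in this assay. It differs from compound 3 in one place: fluoro in place of hydrogen on an aromatic carbon, on the ring that carries the trifluoromethyl group. Within the data shown here, no measured pair shows a step of this kind, so no size of step can be read from the numbers; a change of one fluorine on an aromatic carbon would be expected to give a step no larger than the scatter, in no set direction.

The value of compound 4 is therefore estimated near that of compound 3, because compound 3 gives 2410 nM, at 2000 nM with a range of 800 nM to 5000 nM. The expected step from compound 3 to compound 4 is a 1.2-fold lower number from compound 3 to compound 4 (0.08 log units; within the scatter).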

Compound 4, half-maximal inhibitory concentration: 1590 nM
Estimate against measurement, compound 4: 1.3-fold (0.10 log units) above; low and high end bracket the measured number.
By their numbers in this assay, from the lowest: compounds 1, 4, 3 and 2 (each within the scatter of the next).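

In a 1.5-fold lower number from compound 3 to compound 4 (0.18 log units; within the scatter) in this assay, the series gains its first step that can be read at a single place, and this step lies within the scatter. Among these compounds, this aromatic carbon, meta to a trifluoromethyl group, therefore takes fluoro in place of hydrogen with no change that can be told from repeat measurement, so the earlier compounds' lack of a readable step is now replaced by one small, uncertain step of unsettled direction. No measurement among these compounds bears on the cause of this step.

As far as these compounds go, whether an amine, a carboxylic acid or a methoxy group at this same carbon would give a step beyond the scatter remains open. Also open, from the compounds shown here alone, is whether fluoro here would give a similar step on a different core, such as that of compound 1.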